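The source may hold more compounds than are shown below. What is called first, only, known or untested is meant among the compounds shown, and "the series" means these compounds.

Two compounds measured in an assay on microsomes from liver for inhibition of 3-hydroxy-3-methylglutaryl-coenzyme A reductase (Rattus norvegicus) (a higher number here means a weaker inhibitor, a lower number a stronger inhibitor), set the frame. Compound 1 `Cc1ccc(CNC(=O)c2nn(-c3ccc(F)cc3)c(CC[C@@H](O)C[C@@H](O)CC(=O)O)c2C(C)C)cc1` gives 2.5 nM in this assay. Among the compounds with values here, compound 2 `CC(C)c1c(C(=O)NCc2cccc(F)c2F)nn(-c2ccc(F)cc2)c1OC[C@@H](O)C[C@@H](O)CC(=O)O`, which carries a 2,3-difluorobenzyl amide and an oxymethylene link to the dihydroxy acid, gives 2 nM in this assay; that number sits within the scatter of the one for compound 1, so nothing separates the two on the data in hand. The next compound, compound 3 `Cc1ccc(CNC(=O)c2nn(-c3ccc(F)cc3)c(OC[C@@H](O)C[C@@H](O)CC(=O)O)c2C(C)C)cc1`, keeps the oxymethylene link of compound 2 and changes only the amide end: 4-methylphenyl in place of 2,3-difluorophenyl on a saturated chain carbon bound to an amide-type nitrogen. Within the data shown here, no such step between two measured compounds has been recorded, but compound 1 already carries the same 4-methylbenzyl amide and gives 2.5 nM, close to compound 2. The step from compound 2 to compound 3 is therefore expected to be small, a 1.3-fold higher number from compound 2 to compound 3 (0.10 log units; within the scatter), not beyond the scatter in either direction. Compound 3 is expected to give about 2.5 nM in this assay, with a range from 1 nM to 7 nM.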

Compound 3, half-maximal inhibitory concentration: 15 nM
Compound 3: the middle estimate sits 6.0-fold (0.78 log units) below what was measured, and the stated range ends below it.
By their numbers in this assay, from the lowest: compounds 2 and 1 (each within the scatter of the next); then compound 3.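

The near match of the two earlier compounds said nothing about either change alone, and here, with the oxymethylene link held, 4-methylphenyl in place of 2,3-difluorophenyl on a saturated chain carbon bound to an amide-type nitrogen is a real step in this assay, a 7.5-fold higher number from compound 2 to compound 3 (0.88 log units; beyond the scatter). With the 4-methylbenzyl amide held, the other end matters as well: (5-carboxy-2,4-dihydroxypentyl)oxy in place of 6-carboxy-3,5-dihydroxyhexyl on an aromatic carbon gives a 6.0-fold higher number from compound 1 to compound 3 (0.78 log units; beyond the scatter). Nothing at hand accounts for either step.

The compounds shown leave open how the 2,3-difluorobenzyl amide fares on the 6-carboxy-3,5-dihydroxyhexyl chain. They also leave open how a plain benzyl or 4-fluorobenzyl amide would stand on the oxymethylene link.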